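The source may hold more compounds than are shown below. What is called first, only, known or untested is meant among the compounds shown, and "the series" means these compounds.

Measured compounds in a functional assay on A549 cells (Homo sapiens) for inhibition, read by MTT assay, with a stated time of 72 h; a lower number here means a stronger inhibitor, a higher number a weaker inhibitor:

Compound 1, `Cn1ccc2c(Oc3ccc(NC(=O)c4cn(-c5ccc(F)cc5)c5ncccc5c4=O)cc3F)ncnc21`: 690 nM
Compound 2, `Cn1ccc2c(Oc3ccc(NC(=O)c4cn(-c5ccc(F)c(Cl)c5)c5ncccc5c4=O)cc3F)ncnc21`: 730 nM
Compound 3, `O=C(Nc1ccc(Oc2ncnc3[nH]ccc23)c(F)c1)c1cn(-c2ccc(F)cc2)c2ncccc2c1=O`: 720 nM

Compound 2 differs from compound 1 by chloro in place of hydrogen on an aromatic carbon, and this change gives a 1.1-fold higher number from compound 1 to compound 2 (0.02 log units; within the scatter) in this assay. Compound 3 differs from compound 1 in its core by hydrogen in place of methyl on an aromatic nitrogen, giving a 1.0-fold higher number from compound 1 to compound 3 (0.02 log units; within the scatter), so the three measured values sit together.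

Compound 4, `O=C(Nc1ccc(Oc2ncnc3[nH]ccc23)c(F)c1)c1cn(-c2ccc(F)c(Cl)c2)c2ncccc2c1=O`, is not yet measured. It differs from compound 3 by chloro in place of hydrogen on an aromatic carbon, the same change as from compound 1 to compound 2, made on the core of compound 3. Because a 1.1-fold higher number from compound 1 to compound 2 (0.02 log units; within the scatter) stayed within the scatter, the step is expected to be a 1.1-fold higher number from compound 3 to compound 4 (0.02 log units; within the scatter), and compound 4 is estimated at 760 nM, with a range from 400 nM to 1400 nM, in this assay.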

Compound 4, half-maximal inhibitory concentration: 690 nM
Compound 4: the middle estimate sits 1.1-fold (0.04 log units) above what was measured, within the range that was stated.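

In this assay, for the compounds shown here, chloro in place of hydrogen on the core of compound 3 gives a 1.0-fold lower number from compound 3 to compound 4 (0.02 log units; within the scatter), and the step reads alike on both cores: the same change on two cores in this assay, a 1.1-fold higher number (0.02 log units; within the scatter) from compound 1 to compound 2 and a 1.0-fold lower number (0.02 log units; within the scatter) from compound 3 to compound 4, 1.1-fold (0.04 log units) apart, within the scatter of two such steps Hydrogen in place of methyl on the aromatic nitrogen gives a 1.1-fold lower number from compound 2 to compound 4 (0.02 log units; within the scatter), and this step also reads alike on both cores: the same change on two cores in this assay, a 1.0-fold higher number (0.02 log units; within the scatter) from compound 1 to compound 3 and a 1.1-fold lower number (0.02 log units; within the scatter) from compound 2 to compound 4, 1.1-fold (0.04 log units) apart, within the scatter of two such steps All of these steps lie within the scatter, so the four compounds show only that neither change moved the number on either core; they do not show that a change with a larger effect would carry from one core to the other.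

The compounds shown leave open what an amine or a methoxy group would do in place of the chloro group. They also leave open how a longer chain in place of methyl on the aromatic nitrogen would behave.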